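Methyl additions at two chain positions: notes on binding

The source may report more compounds than this note shows. Statements on the series, on what has been measured and on what is new or still open speak of the compounds shown alone.

Compound 1 `CCOC(=O)C1=C(CC)NC(=O)NC1c1ccco1` and compound 2 `CCCC1=C(C(=O)OCC)C(c2ccco2)NC(=O)N1` share one core; compound 3 `CCOC(=O)C1=C(C)N(C)C(=O)NC1c1cccs1` and compound 4 `CC1=C(C(=O)OC(C)C)C(c2cccs2)NC(=O)N1C` share another, and the difference between the two cores is not broken down here. In an assay on CHO cells for displacement of a labelled ligand from adenosine receptor A1 (Homo sapiens), with a stated time of 60 min, tested at 10 uM (a lower number here means less inhibition, a higher number more inhibition at the concentration tested (going by the name of the read-out)), compound 1 gives 29% and compound 2 gives 50%; the step of a number 21 percentage points higher from compound 1 to compound 2 (beyond the scatter) goes with methyl in place of hydrogen on a saturated chain carbon, two bonds along the chain from a double-bonded ring carbon. In this assay compound 3 gives 2%, the lowest of the three measured numbers, and its gaps to compound 1 and to compound 2 both lie beyond the scatter.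

Compound 4 differs from compound 3 by methyl in place of hydrogen on a saturated chain carbon bound to an oxygen next to a carbonyl group and a saturated chain carbon. This is the same kind of change as that from compound 1 to compound 2, a methyl entering for a hydrogen on a saturated chain carbon, but the place differs: in the earlier pair the carbon sits two bonds along the chain from a double-bonded ring carbon, here it is bound to an oxygen next to a carbonyl group and a saturated chain carbon. Among the measured compounds shown here, only one earlier step is available, made on a different core at a different place, so it is a weak guide. Expected in this assay is a number 8 percentage points higher from compound 3 to compound 4 (within the scatter), smaller than the measured gain because compound 3 starts from 2%. Compound 4 is estimated at 10% in this assay, with an expected range from 0% to 30%.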

Compound 4, a percentage reported as inhibition, at one concentration (the size of the read-out at that concentration, not a potency): 22%
Beside the measured number, compound 4's estimate is 12 percentage points below it; the measured number falls inside the stated range.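

In this assay, the change from ethoxycarbonyl to isopropoxycarbonyl goes with a number 20 percentage points higher from compound 3 to compound 4 (beyond the scatter). Set beside the earlier methyl addition, this step shows that a methyl in place of a hydrogen on a saturated chain carbon goes with a gain of similar size on both cores: the same change on two cores in this assay, a number 21 percentage points higher (beyond the scatter) from compound 1 to compound 2 and a number 20 percentage points higher (beyond the scatter) from compound 3 to compound 4, 1 percentage points apart, within the scatter of two such steps This does not show that a methyl at one given place transfers between cores, since each core supplies a single pair and the methyl enters at a different place in each, two bonds along the chain from a double-bonded ring carbon in one pair and on a carbon bound to an oxygen next to a carbonyl group and a saturated chain carbon in the other; the read-out is also a single-concentration inhibition and not a potency.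

The compounds shown leave open whether each methyl addition gives a similar step at its own place on the other core, and whether the two additions together on one core would add up. Also open, going by these compounds, is how a longer chain on the ester oxygen, or a carboxylic acid in place of the ester, would read in this assay.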